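The compounds below may be only part of what the source reports. "The series", "measured", "known", "first", "only" and "open" are said of these compounds alone.

Measured in a functional assay on DU-145 cells (Homo sapiens) for inhibition, read by trypan blue exclusion, with a stated time of 96 h (on this read-out higher numbers stand for weaker inhibition of growth and lower numbers for stronger inhibition of growth), so far:
- compound 1 `O=C(/C(=C\c1ccc([N+](=O)[O-])c(O)c1)SCc1ccc(Br)cc1)c1ccc([N+](=O)[O-])cc1` gives 1000 nM
- compound 2 `O=C(/C(=C\c1ccc(O)c([N+](=O)[O-])c1)SCc1ccc(Br)cc1)c1ccc(Br)cc1` gives 10000 nM
- compound 3 `O=C(/C(=C\c1ccc([N+](=O)[O-])c(O)c1)SCc1ccc(Br)cc1)c1ccc(Br)cc1` gives 10000 nM

Compound 3 sits level with compound 2, the two sharing the highest number of the three, while compound 1 lies well under them. The next change leads to compound 4 `O=C(/C(=C\c1cc(Cl)c(O)c(Cl)c1)SCc1ccc(Br)cc1)c1ccc(Br)cc1` and reads 3,5-dichloro-4-hydroxyphenyl in place of 3-hydroxy-4-nitrophenyl on a double-bonded chain carbon bound to a double-bonded chain carbon in structural terms. Among the compounds with values here, two measured steps bear on it. The closest is the exchange of 4-hydroxy-3-nitrophenyl for 3-hydroxy-4-nitrophenyl at the same place, which gave no change at the digits printed from compound 2 to compound 3 (within the scatter) and so offers no sign of a large step there. The other is a 10-fold higher number from compound 1 to compound 3 (1.00 log units; beyond the scatter) for bromo in place of nitro on an aromatic carbon, which is larger but lies at another place in the molecule and carries over only weakly. Within the data shown here, no measured compound holds chlorine, so the entering group has no direct precedent. In this assay no step beyond the scatter is expected, with a slight lean towards a lower number. The expected change is a 1.7-fold lower number from compound 3 to compound 4 (0.22 log units; within the scatter) as an estimate, within the scatter. For compound 4 the estimated value is 6000 nM with an expected range of 1500 nM to 20000 nM in this read-out.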

Compound 4, concentration for 50% growth inhibition: 10000 nM
Compound 4: middle estimate off by 1.7-fold (0.22 log units), on the low side; the range from low to high includes it.
By their numbers in this assay, from the lowest: compound 1; then compounds 2, 3 and 4 (each within the scatter of the next).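

In this assay, 3,5-dichloro-4-hydroxyphenyl in place of 3-hydroxy-4-nitrophenyl gives no change at the digits printed from compound 3 to compound 4 (within the scatter) and the same group in place of 4-hydroxy-3-nitrophenyl gives no change at the digits printed from compound 2 to compound 4 (within the scatter) at this place on a double-bonded chain carbon bound to a double-bonded chain carbon. With the bromo group on the other aromatic ring held fixed, a group with no nitro and two chlorines therefore reads the same as both nitro-bearing groups, which extends the flat reading from a shift of the nitro and hydroxy groups to a different set of substituents. Within the data shown here, the only step beyond the scatter remains a 10-fold higher number from compound 1 to compound 3 (1.00 log units; beyond the scatter) at the other aromatic ring. No evidence on the series accounts for this flat reading.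

Still open, from the compounds shown here alone, is whether 3,5-dichloro-4-hydroxyphenyl would keep the lower number of compound 1 alongside the nitro group on the other aromatic ring. Also open, going by these compounds, is whether an amine or a carboxylic acid in place of the hydroxy group at this place would move the number at all.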